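Extending Compound 3 With a Second Aromatic Ring

The source may report more compounds than this note shows. Statements on the series, on what has been measured and on what is new or still open speak of the compounds shown alone.

Of the compounds shown here, three of a shared core have been measured in an ADME assay on Vero cells (Chlorocebus sabaeus) for cytotoxicity, read by MTT assay, with a stated time of 48 h; a lower number here means that less compound is tolerated, a higher number that more compound is tolerated. Compound 1 `O=C(NC1(c2ccccc2)CC1)c1ccc([N+](=O)[O-])o1` gives 46000 nM. Compound 2 `O=C(NC(=O)c1ccc([N+](=O)[O-])o1)c1ccccc1` gives 3000 nM in this assay. Compound 3 `CC(C)(NC(=O)c1ccc([N+](=O)[O-])o1)c1ccc(Cl)cc1` gives 81000 nM, the highest of the three numbers; its nearest neighbour is compound 1, whose number lies within the scatter of it, while compound 2 lies far below it, beyond the scatter.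

Compound 4 `CC(C)(NC(=O)c1ccc([N+](=O)[O-])o1)c1ccc(Oc2ccc(Cl)cc2)cc1` has not yet been measured in this assay. It differs from compound 3 in one place: 4-chlorophenoxy in place of chloro on an aromatic carbon. Among the compounds with values here, no step between two measured compounds of this set shows the effect of such a change, so the expectation rests on compound 3 alone. Since the numbers of compound 3 and compound 1 in this assay sit close together, a large effect from a single substitution seems unlikely, and a step of the size a 2.0-fold lower number from compound 3 to compound 4 (0.31 log units; beyond the scatter) is expected, mildly downward or not beyond the scatter. Compound 4 is therefore estimated at 40000 nM, within a range from 12000 nM to 130000 nM.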

Compound 4, half-maximal cytotoxic concentration: 67000 nM
Estimate against measurement, compound 4: 1.7-fold (0.22 log units) below; the range from low to high includes it.
By their numbers in this assay, from the lowest: compound 2; then compounds 1, 4 and 3 (each within the scatter of the next).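

The aromatic carbon that carries chloro in compound 3 turns out to tolerate a much larger group: 4-chlorophenoxy in place of chloro brings in a second six-membered aromatic ring and a hydrogen-bond acceptor, yet gives a 1.2-fold lower number from compound 3 to compound 4 (0.08 log units; within the scatter) in this assay. Within the data shown here, the earlier compounds held no step at this position, so this is the first reading of it, and at this carbon, para to a large group, the added ring leaves the number within the scatter of compound 3. No measurement in hand speaks to what lies behind this result.

As far as these compounds go, whether this holds beyond a chlorinated second ring stays open, since an amine or a carboxylic acid on the same aromatic carbon could give a different number. From the compounds shown here alone, the same change on the core of compound 1 also remains open.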